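Methyl on the Hydroxy Oxygen of Compound 2

This account rests on a few compounds, and the source may have more. Where it says the series, first, only, none or still open, it means among the compounds named here.

In a functional assay on HCT-116 cells (Homo sapiens) for inhibition, read by microscopy and wound healing assay, with a stated time of 72 h (a lower number here means that less compound is needed, a higher number that more compound is needed for the effect), compound 1 (`COc1ccc(S(=O)(=O)Nc2ccc3oc(-c4ccc(NC(=O)c5ccc(Cl)s5)cc4)nc3c2)cc1`) gives 5700 nM and compound 2 (`O=C(Nc1ccc(Sc2nc3ccccc3s2)c(Cl)c1)c1cccc(Br)c1O`) gives 2000 nM as the lower of the two numbers, a gap beyond the usual scatter. Compound 3 (`COc1c(Br)cccc1C(=O)Nc1ccc(Sc2nc3ccccc3s2)c(Cl)c1`) differs from compound 2 by a single change (methyl in place of hydrogen on an oxygen on an aromatic ring): methyl in place of hydrogen on an oxygen on an aromatic ring, hydroxy to methoxy. Going by the values given here, no measured pair shows this change, so only a modest rise in the number is expected, near the edge of the scatter. The estimated change is a 2.0-fold higher number from compound 2 to compound 3 (0.30 log units; within the scatter) in this measure. Compound 3 is expected at 4000 nM (estimated range 1500 nM to 12000 nM) in this assay once tested.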

Compound 3, half-maximal effective concentration: 5500 nM
Compound 3: middle estimate off by 1.4-fold (0.14 log units), on the low side, within the range that was stated.
By their numbers in this assay, from the lowest: compound 2; then compounds 3 and 1 (each within the scatter of the next).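

Methyl in place of hydrogen on this oxygen gives the first measured step at this position. In this assay the change from hydroxy to methoxy brings a 2.8-fold higher number from compound 2 to compound 3 (0.44 log units; beyond the scatter) and so shows that, in this pair, more compound is needed once the hydrogen on this oxygen is replaced. No available evidence accounts for this rise. Going by these compounds, what an amine in place of the hydroxy would give remains open. So does the effect of a longer chain, such as ethyl, on this oxygen.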